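Carboxy for hydroxy on a fused quinoline-type amide core

The source may hold more compounds than are shown below. What is called first, only, known or untested is meant among the compounds shown, and "the series" means these compounds.

Of the compounds shown here, three have been measured in a functional assay on A-375 cells (Homo sapiens) for antiproliferative activity, read by MTT assay, with a stated time of 24 h, tested at 0.05 ug/mL; a lower number here means a weaker effect, a higher number a stronger effect of the compound at the concentration tested. Compound 1 `Cc1ccc2nc(C(=O)Nc3c(F)cc(-c4cccc(F)c4)cc3F)c(C)c(O)c2c1` gives 0.96%. Compound 3 `Cc1ccc2nc(C(=O)Nc3c(F)cc(-c4cccc(F)c4)cc3F)c(C)c(C(=O)O)c2c1` differs from compound 1 only by carboxy in place of hydroxy on an aromatic carbon; in the same assay compound 3 gives 0.35%. The step of a number 0.6 percentage points lower from compound 1 to compound 3 (within the scatter) thus lies within the ordinary scatter, and nothing can be read from it beyond the fact that both numbers are small. Compound 2 `COc1ccc2nc(C(=O)Nc3ccc(-c4ccccc4)cc3)c(C)c(O)c2c1` gives 1.98%. Compound 2 and compound 1 differ by more than a single group, and the difference between the two cores is not broken down here. Compound 2 holds the highest of the three numbers, but its gap to compound 1 and to compound 3 lies within the scatter, so no order among the three can be claimed.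

Compound 4 `COc1ccc2nc(C(=O)Nc3ccc(-c4ccccc4)cc3)c(C)c(C(=O)O)c2c1` has not yet been measured. It differs from compound 2 by carboxy in place of hydroxy on an aromatic carbon, the same change as that from compound 1 to compound 3, made at a place described in the same words. Given that the earlier step was flat, the step is expected to be a number 0.6 percentage points lower from compound 2 to compound 4 (within the scatter) because the same change gave a number 0.6 percentage points lower from compound 1 to compound 3 (within the scatter). Within the data shown here, compound 4 is therefore estimated to give 1.4%, with a likely range from 0% to 8%, resting on only one prior example of the change.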

Compound 4, a percentage reported as inhibition, at one concentration (the size of the read-out at that concentration, not a potency): 1.26%
Beside the measured number, compound 4's estimate is 0.1 percentage points above it; measured number inside the range.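

In this assay, among these compounds, putting carboxy in place of hydroxy on the core of compound 2 gave a number 0.7 percentage points lower from compound 2 to compound 4 (within the scatter), so the change, made on an aromatic carbon opposite the ring nitrogen, again left no step that can be told from the scatter. Set beside the earlier case, the two steps do not differ, and the change carried over from one core to the other with the same flat outcome: the same change on two cores in this assay, a number 0.6 percentage points lower (within the scatter) from compound 1 to compound 3 and a number 0.7 percentage points lower (within the scatter) from compound 2 to compound 4, 0.1 percentage points apart, within the scatter of two such steps This shows agreement between two flat steps on two cores at one concentration, where all four numbers are small; it does not show that a step of real size would carry across these cores, nor does it say anything about a third core.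

The compounds shown leave open whether another group on that aromatic carbon, such as an amine, a primary amide or a longer chain, would give a step beyond the scatter. They also leave open how hydroxy and carboxy compare on these cores under conditions in which the compounds give a larger read-out, since a flat step here gives no order between the two groups.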